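Aryl exchange from compound 2 to compound 3

The source may report more compounds than this note shows. Statements on the series, on what has been measured and on what is new or still open speak of the compounds shown alone.

The series shares one core and varies only the aryl group on an aromatic nitrogen. Compound 1 `C/C(=C\CC/C(C)=C/CC[C@@H]1[C@@]2(C)CCC(=O)C(C)(C)[C@H]2CC[C@@]1(C)O)CC/C=C(\C)C(=O)OCc1cn(-c2ccccc2[N+](=O)[O-])nn1` reads > 150000 nM in a functional assay on DU-145 cells (Homo sapiens) for antiproliferative activity, read by MTT assay, with a stated time of 48 h (on this read-out lower numbers stand for stronger inhibition and higher numbers for weaker inhibition), and this is a limit of the assay, not a number. Within the data shown here, compound 2 `C/C(=C\CC/C(C)=C/CC[C@@H]1[C@@]2(C)CCC(=O)C(C)(C)[C@H]2CC[C@@]1(C)O)CC/C=C(\C)C(=O)OCc1cn(-c2cccc(Cl)c2)nn1` gives 103000 nM in this assay, the only true number available so far, so it cannot yet be ranked on a scale of measured values.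

Compound 3 `C/C(=C\CC/C(C)=C/CC[C@@H]1[C@@]2(C)CCC(=O)C(C)(C)[C@H]2CC[C@@]1(C)O)CC/C=C(\C)C(=O)OCc1cn(-c2ccccc2F)nn1` carries 2-fluorophenyl in place of 3-chlorophenyl on an aromatic nitrogen.

Among the measured compounds shown here, only one measured step bears on this change: an at least 1.4-fold lower number from compound 1 to compound 2 (0.16 log units; that floor lies within the scatter), with 3-chlorophenyl in place of 2-nitrophenyl on an aromatic nitrogen. It involves the same aryl position, but it is bounded only on one side and offers no evidence for a fluorine or chlorine effect. No step beyond the scatter is therefore expected in this assay, and no direction can be favoured. The expected change is a 1.1-fold higher number from compound 2 to compound 3 (0.05 log units; within the scatter). A result reported only as a limit would also be unsurprising. For compound 3 the estimate is 115000 nM, with an expected range of 60000 nM to 180000 nM.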

Compound 3, half-maximal inhibitory concentration: > 150000 nM
Compound 3: no number, only a limit (the forecaster's own chance of this, stated with the estimate: 35%); middle value at least 1.3-fold (0.11 log units) from the limit.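

In this assay compound 3 gives > 150000 nM, which is a limit of the assay and not a number. Exchanging 3-chlorophenyl for 2-fluorophenyl on the aromatic nitrogen gives an at least 1.4-fold higher number from compound 2 to compound 3 (0.16 log units; that floor lies within the scatter), so this change is bounded on one side only and its floor stays within the scatter, which means that neither this step nor the earlier one establishes a real difference between aryl groups. The step between the two limits of compound 1 and compound 3 cannot be read, and compound 2 remains the only compound in the set with a true number, so the new result adds a second aryl group at the ceiling rather than a second point on a scale: the limit of > 150000 nM in this assay, at which 2 of the 3 values shown sit.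

Still open, from the compounds shown here alone, is whether any aryl group at this position can bring the number clearly down from that ceiling, for example a 3-aminophenyl or a 3-carboxyphenyl group, or a benzyl group that sets the ring one carbon further out. The change also alters both the halogen and its place on the ring, and 3-fluorophenyl and 2-chlorophenyl would be needed to separate the two.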